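Swapping the bromophenyl of compound 2 for dimethoxyphenyl

The source may report more compounds than this note shows. Statements on the series, on what has been measured and on what is new or still open speak of the compounds shown alone.

Measured in a functional assay on FM3A cells (Mus musculus) for antiproliferative activity; a lower number here means a stronger inhibitor, a higher number a weaker inhibitor:
Compound 1 `COc1cc(C(=O)c2sc(-c3ccc(-c4ccccc4)cc3)cc2N)cc(OC)c1OC`: > 10000 nM (a limit, not a number)
Compound 2 `COc1cc(C(=O)c2sc(-c3ccc(Br)cc3)cc2N)cc(OC)c1OC`: 150 nM

In this assay, among the compounds with values here, compound 2 gives 150 nM, the only true number so far. Compound 1 marks only (the limit of > 10000 nM in this assay, at which 1 of the 2 values shown sits).

The next compound is compound 3 `COc1ccc(-c2cc(N)c(C(=O)c3cc(OC)c(OC)c(OC)c3)s2)cc1OC`, not yet measured. It carries one change from compound 2: 3,4-dimethoxyphenyl in place of 4-bromophenyl on an aromatic carbon. In words, 3,4-dimethoxyphenyl stands in place of 4-bromophenyl on an aromatic carbon.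

Within the data shown here, one measured step touches this same group: an at least 66-fold lower number from compound 1 to compound 2 (1.82 log units; beyond the scatter). It is large, but it involves a different replacement and gives only a loose guide. Because of an at least 66-fold lower number from compound 1 to compound 2 (1.82 log units; beyond the scatter) a change at this place is expected to matter, and a moderate move toward a higher number seems likely.

For compound 3 the expected value is 500 nM, with an estimated range of 90 nM to 3500 nM. This estimate amounts to a 3.3-fold higher number from compound 2 to compound 3 (0.52 log units; beyond the scatter).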

Compound 3, half-maximal inhibitory concentration: 72 nM
Beside the measured number, compound 3's estimate is 6.9-fold (0.84 log units) above it; measured number outside the range, below it.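

In this assay, replacing 4-bromophenyl with 3,4-dimethoxyphenyl on the aromatic carbon next to the ring sulfur gives a 2.1-fold lower number from compound 2 to compound 3 (0.32 log units; beyond the scatter). The earlier step showed only that this position is sensitive to change; this one shows that a substituted phenyl other than 4-bromophenyl can stand here and give a lower number, even though the entering group has more heavy atoms and, unlike the bromo compound's group, carries hydrogen-bond acceptors. Compound 1 remains a limit, not a number, so the compounds at this position still have only two true values: the limit of > 10000 nM in this assay, at which 1 of the 3 values shown sits.

Which of the two methoxy groups matters stays open, since the 3-methoxyphenyl and 4-methoxyphenyl analogues are absent from the compounds shown. Also open, from the compounds shown here alone, is how an amine, such as a 4-aminophenyl group, or a carboxylic acid at this position would read in this assay.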